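Alkyl on the ring amine nitrogen and clearance

The source may hold more compounds than are shown below. What is called first, only, known or untested is meant among the compounds shown, and "the series" means these compounds.

Compound 1 `COc1cc2c(cc1N1C[C@@H](C)N(C)[C@@H](C)C1)N(C(=O)c1ccc(-c3cccc(C)n3)c3ccccc13)CC2` and compound 2 `COc1cc2c(cc1N1C[C@@H](C)N[C@@H](C)C1)N(C(=O)c1ccc(-c3cccc(C)n3)c3ccccc13)CC2` share one core and differ only at a ring amine nitrogen. In an in vitro ADME assay on the whole organism (microsomes, liver) for metabolic stability, with Rattus norvegicus as the target (a lower number here means slower removal, a higher number faster removal of the compound), compound 1 gives 46 mL.min-1.g-1 and compound 2 gives 12 mL.min-1.g-1; the step of a 3.8-fold lower number from compound 1 to compound 2 (0.58 log units; beyond the scatter) is the only measured one, and compound 2 stands at the lower of the two numbers. Compound 3 `CCN1[C@H](C)CN(c2cc3c(cc2OC)CCN3C(=O)c2ccc(-c3cccc(C)n3)c3ccccc23)C[C@@H]1C` carries the change (ethyl in place of hydrogen on an amine nitrogen in a ring). Going by the values given here, the one step that bears on it ran the opposite way, so the number for compound 3 is expected to rise again, estimated as 50 mL.min-1.g-1 (range 20 mL.min-1.g-1 to 120 mL.min-1.g-1), a step of a 4.2-fold higher number from compound 2 to compound 3 (0.62 log units; beyond the scatter) in this assay.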

Compound 3, intrinsic clearance in microsomes: 45 mL.min-1.g-1
The estimate for compound 3 lay 1.1-fold (0.05 log units) above the measured number, within the range that was stated.
By their numbers in this assay, from the lowest: compound 2; then compounds 3 and 1 (each within the scatter of the next).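

In this assay ethyl on the amine nitrogen brings a 3.8-fold higher number from compound 2 to compound 3 (0.57 log units; beyond the scatter) and so the gap to the free amine is not particular to methyl. The comparison with the methyl compound reads a 1.0-fold lower number from compound 1 to compound 3 (0.01 log units; within the scatter) and methyl and ethyl at this nitrogen cannot be told apart here. Nothing available explains either step. Open, as far as these compounds go, is whether a longer chain, a cyclopropyl group or an acetyl group on this nitrogen would sit with compound 1 and compound 3 or nearer compound 2.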